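Shortening the ether chain: from nonyl toward propyl

The compounds below may be only part of what the source reports. "The series", "measured", "known", "first", "only" and "open" are said of these compounds alone.

Measured compounds:
Compound 1 `CCCOc1cc([N+](=O)[O-])ccc1N(C)S(C)(=O)=O` gives 760 nM in an assay on SK-BR-3 cells for inhibition of Aromatase (Homo sapiens); a higher number here means a weaker inhibitor, a lower number a stronger inhibitor.
Compound 2 `CCCCCCCCCOc1cc([N+](=O)[O-])ccc1N(C)S(C)(=O)=O` gives 3960 nM in this assay.

Compound 2 carries the longer chain on the ring oxygen and stands at the highest number of the two, the weaker inhibitor; the step of a 5.2-fold higher number from compound 1 to compound 2 (0.72 log units; beyond the scatter) describes how far it lies from compound 1.

Compound 3 `CCCCCCOc1cc([N+](=O)[O-])ccc1N(C)S(C)(=O)=O` is not yet measured. It differs from compound 2 in one place: hydrogen in place of propyl on a saturated chain carbon, six bonds along the chain from an oxygen on an aromatic ring. Said another way, the chain is cut back from nonyl to hexyl, so compound 3 sits between compound 1 and compound 2 in chain length.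

Among the measured compounds shown here, only one measured step bears on this change: lengthening the chain from compound 1 to compound 2, the step of a 5.2-fold higher number from compound 1 to compound 2 (0.72 log units; beyond the scatter), which is modest but beyond the scatter. Removing part of that added length should therefore move the number back toward compound 1, giving a lower number than compound 2, of a size smaller than that step, though the outcome could also stay within the scatter of either neighbour.

Compound 3 is thus expected to give about 1700 nM in this assay, with a range from 800 nM to 3600 nM, an estimated step of a 2.3-fold lower number from compound 2 to compound 3 (0.37 log units; beyond the scatter).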

Compound 3, half-maximal inhibitory concentration: 4490 nM
Compound 3: middle estimate off by 2.6-fold (0.42 log units), on the low side; measured number outside the range, above it.
By their numbers in this assay, from the lowest: compound 1; then compounds 2 and 3 (each within the scatter of the next).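

Cutting the chain back from nonyl to hexyl gives a 1.1-fold higher number from compound 2 to compound 3 (0.05 log units; within the scatter) in this assay, so on these numbers the two long chains cannot be told apart. The hexyl chain already carries the full loss seen with the nonyl chain, at a 5.9-fold higher number from compound 1 to compound 3 (0.77 log units; beyond the scatter) against the propyl chain, which means that across these three compounds the number does not climb steadily with chain length: the rise lies somewhere between propyl and hexyl, and no further rise appears from hexyl to nonyl. No measurement at hand explains why the ether chain behaves this way.

Where between propyl and hexyl the rise sets in stays open, and a butyl or pentyl chain on the ring oxygen would help to locate it. Also open, as far as these compounds go, is whether an ethyl or methyl chain would give a lower number than compound 1 does, and how a chain ending in an amine or a carboxylic acid would compare with these plain chains.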